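This account rests on a few compounds, and the source may have more. Where it says the series, first, only, none or still open, it means among the compounds named here.

Measured so far:

Compound 1 `CCN1CCN(C(=S)SCC(O)Cn2c([N+](=O)[O-])cnc2C)CC1` — in a toxicity assay on HeLa cells (Homo sapiens) for cytotoxicity, read by MTT assay, with a stated time of 24 h (a higher number here means a weaker inhibitor, a lower number a stronger inhibitor), compound 1 gives > 5000000 nM, which is a limit of the assay and not a number.
Compound 2 `Cc1ncc([N+](=O)[O-])n1CC(O)CSC(=S)N1CCCC(C)C1` — in this assay compound 2 gives 609000 nM.
Compound 3 `CCN1CCN(C(=S)SCC(O)Cn2cc([N+](=O)[O-])nc2C)CC1` — in this assay compound 3 gives > 5000000 nM, again a limit rather than a number.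

Compound 1 and compound 2 differ in one place: 3-methylpiperidin-1-yl in place of 4-ethylpiperazin-1-yl on a thiocarbonyl carbon. That change produced an at least 8.2-fold lower number from compound 1 to compound 2 (0.91 log units; beyond the scatter), though the size is only a lower bound, because compound 1 sits at the limit of > 5000000 nM in this assay, at which 2 of the 3 values shown sit.

Compound 3 shares its atoms with compound 1 but joins them differently; the difference between the two cores is not broken down here. Compound 4 `Cc1nc([N+](=O)[O-])cn1CC(O)CSC(=S)N1CCCC(C)C1` stands to compound 3 as compound 2 stands to compound 1, carrying the same change: 3-methylpiperidin-1-yl in place of 4-ethylpiperazin-1-yl on a thiocarbonyl carbon. Because compound 3 also sits at the limit of > 5000000 nM in this assay, at which 2 of the 3 values shown sit, the size of the step to compound 4 cannot be fixed closely, only estimated by analogy with the step from compound 1 to compound 2, which gives a number for compound 2 while compound 1 gives only a limit.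

The expected step from compound 3 to compound 4 in this assay is therefore estimated at an at least 7.1-fold lower number from compound 3 to compound 4 (0.85 log units; beyond the scatter). Compound 4 is expected to give about 700000 nM, within roughly 150000 nM to 3500000 nM, with a fair chance that only a limit is reported, as for compound 3.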

Compound 4, half-maximal inhibitory concentration: 2700000 nM
Estimate against measurement, compound 4: 3.9-fold (0.59 log units) below; the range from low to high includes it.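

In this assay, the swap of 4-ethylpiperazin-1-yl for 3-methylpiperidin-1-yl on a thiocarbonyl carbon, already seen on the core of compound 1, gives on the second core an at least 1.8-fold lower number from compound 3 to compound 4 (0.26 log units; that floor lies within the scatter). Compound 3 gives > 5000000 nM, which is a limit of the assay and not a number, and so the true step could be larger than this floor. The change therefore goes with a lower number on both cores, but a firm shift beyond the scatter is printed only for the first core, and nothing shows that the change is worth the same amount on each: the same change on two cores in this assay, an at least 8.2-fold lower number (0.91 log units; beyond the scatter) from compound 1 to compound 2 and an at least 1.8-fold lower number (0.26 log units; that floor lies within the scatter) from compound 3 to compound 4; the limit leaves it open whether they differ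

The compounds shown also leave open which part of the change matters, the nitrogen in the ring or the methyl and ethyl groups, since these differences all arrive together in a single swap. A plain piperidin-1-yl or a morpholin-4-yl on the same thiocarbonyl carbon, on each of the two cores, would be needed to separate these parts and to show whether the two cores respond alike.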